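Inverting one stereocentre: compound 3 to compound 4

The source may report more compounds than this note shows. Statements on the series, on what has been measured and on what is new or still open speak of the compounds shown alone.

Measured in a functional assay on Vero cells (Chlorocebus sabaeus) for cytotoxicity; on this read-out higher numbers stand for weaker inhibition and lower numbers for stronger inhibition:
- Compound 1 `Nc1ccn([C@H]2CC(F)(F)[C@H](CO)O2)c(=O)n1`: > 100000 nM
- Compound 2 `OC[C@@H]1O[C@@H](n2cnc3c(O)ncnc32)CC1(F)F`: > 100000 nM
- Compound 3 `Nc1ncnc2c1ncn2[C@@H]1C=C(F)[C@H](CO)O1`: > 100000 nM

The three compounds share one feature: the limit of > 100000 nM in this assay, at which 3 of the 3 values shown sit. Going by these compounds, for compound 3, the reading of > 100000 nM is a limit and not a number, so its true position in this assay remains unknown.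

Compound 4 `Nc1ncnc2c1ncn2[C@H]1C=C(F)[C@H](CO)O1` is related to compound 3 by a single change: the two compounds have the same atoms and bonds and differ only in configuration as drawn: 1 of 2 stereo elements differ; a stereocentre at a saturated ring carbon is drawn S in compound 3 and R in compound 4. Within the data shown here, no measured pair shows the size of such a change. The expected result is therefore no shift beyond the scatter, and the estimated step is a number no higher from compound 3 to compound 4 (the limit leaves the size open). For compound 4, the estimated value is 100000 nM, with an expected range of 40000 nM to 150000 nM.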

Compound 4, half-maximal inhibitory concentration: > 100000 nM
Compound 4 was reported as a limit; the forecaster's own chance of this, stated with the estimate: 80%; the middle value sits exactly at the limit.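

Compound 4 reads > 100000 nM, which is a limit, and the step between compound 3 and compound 4 cannot be read. The compounds shown leave open where each truly stands in this assay, and whether inverting this stereocentre changes the read-out at all.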